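The source may hold more compounds than are shown below. What is called first, only, known or untested is meant among the compounds shown, and "the series" means these compounds.

Of the compounds shown here, three have been read so far in a functional assay on L929 cells (Mus musculus) for antiproliferative activity, read by MTT assay; on this read-out lower numbers stand for stronger inhibition and higher numbers for weaker inhibition. Compound 1 (`Cc1ccc(S(=O)(=O)N/N=C2/C[C@@H]3CC4(C[C@@H]3C2)OCC(C)(C)CO4)cc1`) gives > 40 ug/mL, which is a limit of the assay and not a number. Compound 2 (`CC(C)(C)[Si](O[C@H]1C[C@H]2CC(=O)C[C@H]2C1)(c1ccccc1)c1ccccc1`) gives > 40 ug/mL, again a limit and not a number. Among the measured compounds shown here, compound 3 (`CC(C)(C)[Si](C)(C)OC1CCCC2C1C(=O)[C@H]1CC(Br)C3(OCCO3)[C@@H]21`) gives 32 ug/mL, the only actual number in the set. The position of compound 2 is therefore known only as a limit, and the overall picture is the limit of > 40 ug/mL in this assay, at which 2 of the 3 values shown sit.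

Compound 4 (`CC(C)(C)[Si](OC1CCCCCC1)(c1ccccc1)c1ccccc1`) differs from compound 2 in one place: a group of 7 heavy atoms (7 carbon; one seven-membered non-aromatic ring of carbon only) in place of a group of 9 heavy atoms (8 carbon, 1 oxygen; 2 five-membered non-aromatic rings of carbon only), on an oxygen. The cycloheptyl group sits on an oxygen whose other neighbours are: silicon. For the measured compounds named here, no measured pair in the set shows what such a swap does. No step beyond the scatter is expected in this assay, and no direction is favoured. The expected step is a step that the limit leaves unreadable from compound 2 to compound 4. For compound 4 the estimate is 45 ug/mL, with an expected range of 25 ug/mL to 80 ug/mL.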

Compound 4, half-maximal inhibitory concentration: 40 ug/mL
Estimate against measurement, compound 4: 1.1-fold (0.05 log units) above, and the stated range covers the measured number.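

In this assay compound 4 gives 40 ug/mL, so this position, the oxygen bound to silicon, now carries a measured number, which compound 2 did not supply. Compound 2 gives > 40 ug/mL, which is a limit of the assay and not a number. Putting cycloheptyl in place of the group on this oxygen gives a number no higher from compound 2 to compound 4 (the limit leaves the size open) and the values remain gathered at the top of the scale: the limit of > 40 ug/mL in this assay, at which 2 of the 4 values shown sit.

Still open, as far as these compounds go, is whether any other group on this oxygen would give a clearly lower number in this assay, for instance a linear hexyl chain, or a cycloheptyl group carrying an amine or a carboxylic acid. Also open, from the compounds shown here alone, is what the tert-butyl and phenyl groups on silicon contribute to the reading.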